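The source may report more compounds than this note shows. Statements on the series, on what has been measured and on what is new or still open speak of the compounds shown alone.

In a functional assay on PC-3 cells (Homo sapiens) for inhibition (on this read-out lower numbers stand for stronger inhibition and higher numbers for weaker inhibition), the three measured compounds read as follows: compound 1 `COc1cc2nc(N3CCN(C(=O)OCc4ccccc4)CC3)nc(N)c2cc1OC` gives 63000 nM; compound 2 `COc1cc2nc(N3CCN(S(=O)(=O)c4ccc(I)cc4)CC3)nc(N)c2cc1OC` gives 15000 nM; compound 3 `COc1cc2nc(N3CCN(S(=O)(=O)c4ccccc4[N+](=O)[O-])CC3)nc(N)c2cc1OC` gives 35000 nM.

Compound 2 stands lowest of these three numbers. Its nearest neighbour is compound 3, reached by a 2.3-fold higher number from compound 2 to compound 3 (0.37 log units; beyond the scatter), and the furthest is compound 1, from which it is reached by a 4.2-fold lower number from compound 1 to compound 2 (0.62 log units; beyond the scatter). Both steps are modest and both lie beyond the scatter.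

Compound 4 `CCCCc1ccc(-c2ccc(S(=O)(=O)N3CCN(c4nc(N)c5cc(OC)c(OC)cc5n4)CC3)cc2)cc1` differs from compound 2 in one place: 4-butylphenyl in place of iodo on an aromatic carbon. The two measured steps bear on this change only loosely. The step from compound 1 to compound 2 concerns the group on the amine nitrogen in the ring, and the step from compound 2 to compound 3 swaps the whole aryl group on the sulfonyl sulfur; neither replaces the iodo on the aromatic carbon with a larger group while keeping the rest. Given that, only a modest change, if any beyond the scatter, is expected in this assay, with a slight lean toward a lower number. Compound 4 is therefore estimated at 8000 nM, within 2000 nM to 40000 nM, meaning an expected 1.9-fold lower number from compound 2 to compound 4 (0.27 log units; within the scatter).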

Compound 4, half-maximal inhibitory concentration: 3400 nM
Beside the measured number, compound 4's estimate is 2.4-fold (0.37 log units) above it; the range from low to high includes it.
By their numbers in this assay, from the lowest: compound 4; then compound 2; then compounds 3 and 1 (each within the scatter of the next).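

In this assay the replacement of iodo by 4-butylphenyl gives a 4.4-fold lower number from compound 2 to compound 4 (0.64 log units; beyond the scatter) and so shows that this aromatic carbon, para to a large group, can carry a much larger group that brings its own aromatic ring without any loss of inhibition. The earlier steps shown here changed the group on the ring nitrogen or the whole aryl group on the sulfonyl sulfur, whereas this one alters only the substituent on that aryl group and keeps the rest of compound 2 in place. Nothing available explains this gain or assigns it to a feature of the new group. The compounds shown leave open whether the added benzene ring or the butyl chain carries the step, a question that a plain phenyl group at this carbon would address. From the compounds shown here alone, it also remains open how a longer chain, or an amine or carboxylic acid at the end of the butyl chain, would read.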